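Ortho-substituted aryl pyrazole carboxamides against secretory phospholipase

The source may report more compounds than this note shows. Statements on the series, on what has been measured and on what is new or still open speak of the compounds shown alone.

Measured compounds:
- compound 1 `NC(=O)c1cc(-c2ccccc2Cl)[nH]n1`: 9330 nM
- compound 2 `Cc1cc(-c2cc(C(N)=O)nn2C)c(C)s1`: 851 nM

In an assay on isolated protein for inhibition of Group 10 secretory phospholipase A2 (Homo sapiens), with a stated time of 30 min (a higher number here means a weaker inhibitor, a lower number a stronger inhibitor), compound 1 gives 9330 nM, the highest of the two numbers in hand. Among the compounds with values here, the nearest neighbour is compound 2, which in this assay gives 851 nM, a gap that lies beyond the scatter; no single-point step connects the two, so the pair is read only by its values.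

Compound 3 `Cc1ccccc1-c1cc(C(N)=O)n[nH]1` is not yet measured. It differs from compound 1 by methyl in place of chloro on an aromatic carbon. Within the data shown here, nothing measured so far bears on this exchange, so no direction is established. The expectation is that the step from compound 1 to compound 3 in this assay, a 1.1-fold higher number from compound 1 to compound 3 (0.03 log units; within the scatter), stays within the scatter. Compound 3 is therefore estimated at 10000 nM, within a range from 3500 nM to 30000 nM.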

Compound 3, half-maximal inhibitory concentration: 2750 nM
The estimate for compound 3 lay 3.6-fold (0.56 log units) above the measured number, outside the stated range (below it).
By their numbers in this assay, from the lowest: compound 2; then compound 3; then compound 1.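

In this assay this position, on an aromatic carbon ortho to a group of 8 heavy atoms, is not indifferent to what it carries: methyl in place of chloro gives a 3.4-fold lower number from compound 1 to compound 3 (0.53 log units; beyond the scatter), a modest step beyond the scatter. The two groups count the same under the structural comparison, one heavy atom each, no hydrogen-bond donors or acceptors and no net charge, so those counts do not separate them, yet the values do. No measurement on hand bears on what lies behind this step.

On these data alone, whether the step extends to other groups at this position, such as ethyl, methoxy or an amine, remains open, since a single exchange sets no trend. Compound 2 has no single-point link to compound 1 or compound 3, so its lower value says nothing about this position.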